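A few compounds are considered here, and "the series" means these few. Any claim that something is new, unique, unknown or untested is made for them only; others in the source may bear on it.

In a physicochemical assay for solubility, read by HPLC, in phosphate buffer, at pH 6.5 (on this read-out lower numbers stand for lower solubility and higher numbers for higher solubility), compound 1 (`COC(=O)C1=C(C)NC(c2nccs2)=NC1(C)c1ccc(S(C)(=O)=O)cc1`) gives 365 ug/mL and compound 2 (`COC(=O)C1=C(C)NC(c2nccs2)=NC1(C)c1ccc(C#N)cc1`) gives 87 ug/mL on the shared core. Within the data shown here, the only measured single-place step is a 4.2-fold lower number from compound 1 to compound 2 (0.62 log units; beyond the scatter) with cyano in place of methylsulfonyl on an aromatic carbon.

Compound 3 (`COC(=O)C1=C(CN2CC3CC2CO3)NC(c2nccs2)=NC1(C)c1ccc(F)cc1`) stands at 564 ug/mL in this assay and lies within the scatter of compound 1 while compound 2 sits clearly lower. Together, compound 3 and compound 1 form the upper end of the numbers so far.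

Among the measured compounds shown here, compound 4 (`COC(=O)C1=C(CN2CCC(C(F)(F)F)C2)NC(c2nccs2)=NC1(C)c1ccc(F)cc1`) differs from compound 3 by a group of 9 heavy atoms (5 carbon, 1 nitrogen, 3 fluorine; one five-membered non-aromatic ring with 1 hetero atom) in place of a group of 7 heavy atoms (5 carbon, 1 nitrogen, 1 oxygen; 2 five-membered non-aromatic rings with 1 hetero atom each), on a saturated chain carbon bound to a double-bonded ring carbon and no measured step touches that place. For the measured compounds named here, the sole guide to size is therefore a 4.2-fold lower number from compound 1 to compound 2 (0.62 log units; beyond the scatter) which comes from a different kind of change at an aromatic carbon, so it is weak evidence.

With compound 3 starting at 564 ug/mL and an oxygen-bearing group leaving, a lower number of modest size, beyond the scatter, is expected in this assay though the data cannot fix the direction firmly. Going by the values given here, the expected outcome is a 4.3-fold lower number from compound 3 to compound 4 (0.64 log units; beyond the scatter) as an estimate of similar size to the one measured step. Compound 4 is estimated at 130 ug/mL with 30 ug/mL to 480 ug/mL as the expected range.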

Compound 4, solubility: 13 ug/mL
Compound 4: middle estimate off by 10-fold (1.00 log units), on the high side, and the stated range ends above it.
By their numbers in this assay, from the lowest: compound 4; then compound 2; then compounds 1 and 3 (each within the scatter of the next).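

In this assay, the saturated chain carbon bound to a double-bonded ring carbon is now shown to be a sensitive place on the shared core: putting 3-(trifluoromethyl)pyrrolidin-1-yl there in place of the group of 7 heavy atoms with 2 five-membered non-aromatic rings gives a 43-fold lower number from compound 3 to compound 4 (1.64 log units; beyond the scatter). Among these compounds, this step is clearly larger than the only other single-place step, a 4.2-fold lower number from compound 1 to compound 2 (0.62 log units; beyond the scatter), which lies on an aromatic carbon, so changes at the chain carbon can move this read-out further than any change seen so far at the aromatic carbon. No measurement on hand bears on what lies behind the step.

The step changes the ring count, the oxygen and the trifluoromethyl all at once, so the compounds shown do not assign its size to any one of these. An unsubstituted pyrrolidine or a morpholine attached through its nitrogen at the same carbon, with the rest of compound 3 kept, would separate loss of the oxygen from entry of the trifluoromethyl.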